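Aryl ether exchange on the shared core of compound 1

The source may report more compounds than this note shows. Statements on the series, on what has been measured and on what is new or still open speak of the compounds shown alone.

Measured compounds:
compound 1, `Nc1cc(N)c2nc(-c3ccccc3)c(Oc3ccc(Cl)c(Cl)c3)nc2c1`, gives 5010 nM in a functional assay on MDA-MB-435 cells (Homo sapiens) for inhibition, read by sulforhodamine B assay, with a stated time of 48 h; a lower number here means a stronger inhibitor of growth, a higher number a weaker inhibitor of growth
compound 2, `COc1ccc(CNc2nc3cc(N)cc(N)c3nc2-c2ccccc2)cc1OC`, gives 1950 nM in this assay

Compound 1 stands highest of the two numbers in this assay. The nearest, compound 2, gives a lower number, and that gap lies beyond the scatter. Among the measured compounds shown here, compounds 1 and 2 differ in more than one place, so no single step connects them.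

Compound 3, `Nc1cc(N)c2nc(-c3ccccc3)c(Oc3ccc(F)cc3)nc2c1`, is to be measured in this assay. It differs from compound 1 by 4-fluorophenyl in place of 3,4-dichlorophenyl on an oxygen on an aromatic ring. For the measured compounds named here, no measured pair in this set traces that change, so nothing in the present numbers points to a direction for it. The expectation is a step of no size beyond the scatter, in either direction. Compound 3 is therefore estimated at 6000 nM, with a range from 2500 nM to 15000 nM. The expected step of a 1.2-fold higher number from compound 1 to compound 3 (0.08 log units; within the scatter) is meant as within the scatter.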

Compound 3, concentration for 50% growth inhibition: 15800 nM
The estimate for compound 3 lay 2.6-fold (0.42 log units) below the measured number; measured number outside the range, above it.
By their numbers in this assay, from the lowest: compound 2; then compound 1; then compound 3.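

On the aryl ether of the shared core, the group on the oxygen is not a silent place in this assay: 4-fluorophenyl in place of 3,4-dichlorophenyl gives a 3.2-fold higher number from compound 1 to compound 3 (0.50 log units; beyond the scatter) and so weakens growth inhibition modestly. Among the compounds shown here, this is the only single-place reading in the set, and it shows that this position responds to the exchange, which the gap between compound 1 and compound 2 could not show. Nothing available explains the step.

The exchange removes chlorine and adds fluorine in one move, so the compounds shown do not separate the two changes; 4-chlorophenyl or plain phenyl on the same oxygen would address that. From the compounds shown here alone, how an amine or a carboxylic acid on this aryl ring would read also remains open.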